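Halogen Swap on the Benzyl Arm: Cytotoxicity Working Notes

The source may report more compounds than this note shows. Statements on the series, on what has been measured and on what is new or still open speak of the compounds shown alone.

Measured so far:
compound 1, `OCc1cn(Cc2cccc(Cl)c2)c2ccccc12`, gives > 31600 nM, a limit of the assay.
compound 2, `OCc1cn(Cc2ccc(Cl)cc2)c2ccccc12`, gives > 31600 nM, a limit of the assay.
compound 3, `OCc1cn(Cc2cccc(Br)c2)c2ccccc12`, gives > 31600 nM, a limit of the assay.

In an ADME assay on T29 cells (Homo sapiens) for cytotoxicity, read by sulforhodamine B assay, with a stated time of 3 days (on this read-out higher numbers stand for weaker inhibition and lower numbers for stronger inhibition), compound 1 reaches only > 31600 nM, which is a limit and not a number. In this assay compound 2 likewise reaches only > 31600 nM, again a limit. Compound 3 stands at > 31600 nM, also a limit. All three values sit at the same point, namely (the limit of > 31600 nM in this assay, at which 3 of the 3 values shown sit).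

The change from compound 1 to compound 3 is bromo in place of chloro on an aromatic carbon. The step that the two limits leave unreadable from compound 1 to compound 3 cannot be read, since both ends are limits. Compound 2 and compound 1 share the same atoms joined differently; the difference between the two cores is not broken down here.

Compound 4, `OCc1cn(Cc2ccc(Br)cc2)c2ccccc12`, is not yet measured. It differs from compound 2 by bromo in place of chloro on an aromatic carbon. The surroundings of the place are not identical: in compound 3 the entering bromo sits meta to a large group, in compound 4 it sits para to a large group, so this is the same kind of change rather than the same change.

The step from compound 2 to compound 4 is expected to be a step that the limit leaves unreadable from compound 2 to compound 4, resting on the unreadable step that the two limits leave unreadable from compound 1 to compound 3 and on (the limit of > 31600 nM in this assay, at which 3 of the 3 values shown sit). Compound 4 is therefore expected at about 45000 nM. For compound 4 the lower end is estimated at 15000 nM. For compound 4 the upper end is estimated at 150000 nM.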

Compound 4, half-maximal inhibitory concentration: > 31600 nM
Compound 4 gave a limit, no number (the forecaster's own chance of this, stated with the estimate: 85%); the middle value does not contradict the limit.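

The step from compound 2 to compound 4 cannot be read, so compound 4 adds no new step, since in this assay both ends are limits and not numbers: the limit of > 31600 nM in this assay, at which 4 of the 4 values shown sit.

The compounds shown leave open whether bromo in place of chloro, or the different placing of the halogen in compound 1 and compound 2, changes cytotoxicity at all, with none of the four giving a number.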